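The source may hold more compounds than are shown below. What is called first, only, known or untested is meant among the compounds shown, and "the series" means these compounds.

Measured so far in a functional assay on K562 cells (Homo sapiens) for antiproliferative activity, read by resazurin assay, with a stated time of 72 h; on this read-out lower numbers stand for stronger inhibition of growth and higher numbers for weaker inhibition of growth:
- compound 1 `CCCCCCCCCCCC/C=C\N(NC(=O)COC)C(=O)CCCCCCCCC`: > 110000 nM (a limit)
- compound 2 `CCCCCCCCCCCC/C=C\N(NC(=O)CCl)C(=O)CCCCCCCCC`: 18400 nM

Going by the values given here, compound 2 at 18400 nM holds the only number. Compound 1 stands at a limit, > 110000 nM.

The next compound to be read is compound 3 `CCCCCCCCCCCC/C=C\N(NC(C)=O)C(=O)CCCCCCCCC`. The change is hydrogen in place of chloro on a saturated chain carbon bound to a carbonyl carbon. One measured step involves that same place: an at least 5.9-fold lower number from compound 1 to compound 2 (0.77 log units; beyond the scatter). It shows that the group there can shift the read-out in this assay, and that chloro gave the lower number of the two. Compound 3 carries neither group, so that step sets only a rough scale. On that scale, a move from compound 2 toward weaker growth inhibition is expected, no larger than about the measured step, and a reading at the limit remains possible. The estimated change is a 3.3-fold higher number from compound 2 to compound 3 (0.51 log units; beyond the scatter), which is expected to lie beyond the scatter. For compound 3 the estimate is 60000 nM, with an expected range of 20000 nM to 150000 nM.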

Compound 3, concentration for 50% growth inhibition: 41900 nM
Compound 3: middle estimate off by 1.4-fold (0.16 log units), on the high side, within the range that was stated.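

In this assay, hydrogen in place of chloro on a saturated chain carbon bound to a carbonyl carbon gives a 2.3-fold higher number from compound 2 to compound 3 (0.36 log units; beyond the scatter), so the chloro gives the lower number at this place, yet a measurable number remains without it. Hydrogen in place of methoxy at the same place gives an at least 2.6-fold lower number from compound 1 to compound 3 (0.41 log units; beyond the scatter); with hydrogen as the reference, the methoxy and chloro groups move the read-out in opposite directions, and the three groups order as chloro, hydrogen, methoxy from lower to higher number, with every step beyond the scatter. Compound 1 stands at a limit, so both steps from it are bounds only: the limit of > 110000 nM in this assay, at which 1 of the 3 values shown sits.

The compounds shown leave open whether another halogen on this carbon, such as bromine or fluorine, would follow chloro, and whether an amine there would read closer to hydrogen or to methoxy. The two long chains of the shared core stay the same in all three compounds, so what a shorter chain on either side would do at this place cannot be read from them.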